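A Methyl Removed from an Aromatic Oxygen: What to Expect

This account rests on a few compounds, and the source may have more. Where it says the series, first, only, none or still open, it means among the compounds named here.

Measured so far:
compound 1, `O=C(Nc1cccc(-n2cc(-c3ccncc3)c(-c3ccc(Cl)c(O)c3)n2)c1)Nc1ccc(Cl)c(Cl)c1`: 1380 nM
compound 2, `COc1cc(-c2nn(-c3cccc(NC(=O)Nc4ccc(Cl)c(C(F)(F)F)c4)c3)cc2-c2ccncc2)ccc1Cl`: 1020 nM
compound 3, `COc1cc(-c2nn(-c3cccc(NC(=O)c4ccccc4)c3)cc2-c2ccncc2)ccc1Cl`: 701 nM

In a functional assay on MOLT-4 cells (Homo sapiens) for inhibition, read by sulforhodamine B assay, with a stated time of 48 h (a higher number here means a weaker inhibitor of growth, a lower number a stronger inhibitor of growth), compound 2 gives 1020 nM. Among the three numbers it sits second highest, and both neighbours lie within the usual scatter of it: compound 1 gives 1380 nM, compound 3 gives 701 nM. For the measured compounds named here, the one step measured in a single place, a 1.5-fold lower number from compound 2 to compound 3 (0.16 log units; within the scatter), concerns the carbonyl end of the molecule and stays within the scatter.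

Compound 4, `O=C(Nc1cccc(-n2cc(-c3ccncc3)c(-c3ccc(Cl)c(O)c3)n2)c1)Nc1ccc(Cl)c(C(F)(F)F)c1`, differs from compound 2 as follows:
hydrogen in place of methyl on an oxygen on an aromatic ring

Going by the values given here, no measured pair differs only in this way. Compound 1 carries the same hydroxy as compound 4 but also a different group on its carbonyl, so its value cannot be read as a step for this change alone; what can be said is that compound 1 and compound 2 give numbers within the scatter of each other. The step from compound 2 to compound 3 bears on the other end of the molecule and tells nothing about the oxygen.

Among the compounds with values here, with no direct precedent, the expected step from compound 2 to compound 4 in this assay is a 1.2-fold higher number from compound 2 to compound 4 (0.07 log units; within the scatter), that is, none beyond the scatter. Compound 4 is therefore estimated to give 1200 nM, within a range from 600 nM to 2400 nM.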

Compound 4, concentration for 50% growth inhibition: 777 nM
The estimate for compound 4 lay 1.5-fold (0.19 log units) above the measured number, within the range that was stated.
By their numbers in this assay, from the lowest: compounds 3, 4, 2 and 1 (each within the scatter of the next).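

In this assay, the change from methoxy to hydroxy on the 4-chloro-3-methoxyphenyl group now has a direct reading, a 1.3-fold lower number from compound 2 to compound 4 (0.12 log units; within the scatter), so in this pair the methyl on the oxygen can be removed without a step beyond the scatter. For the compounds shown here, compound 4 also supplies a pair that the earlier compounds lacked: with the hydroxy held in place, trifluoromethyl in place of chloro on an aromatic carbon gives a 1.8-fold lower number from compound 1 to compound 4 (0.25 log units; within the scatter), so this second single change also stays within the scatter. No supporting measurement is available to explain the size of either step.

The compounds shown leave open whether a longer chain on this oxygen, or an amine in place of the hydroxy, would give a step beyond the scatter, and whether the change from methoxy to hydroxy would read the same with the phenyl carbonyl end of compound 3. They also leave open whether either single change would remain this small in any other read-out or cell line.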